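This account rests on a few compounds, and the source may have more. Where it says the series, first, only, none or still open, it means among the compounds named here.

Among the compounds with values here, in an ADME assay on MT4 cells (Homo sapiens) for cytotoxicity, read by MTT assay, with a stated time of 5 days (a lower number here means that less compound is tolerated, a higher number that more compound is tolerated), compound 1 (`O=C1N(Cc2ccc(Cl)cc2Cl)c2cccn2S(=O)(=O)N1Cc1ccccc1`) gives 218000 nM, the only exact number available so far. Compound 2 (`N#Cc1ccccc1CN1C(=O)N(Cc2cccc(F)c2)S(=O)(=O)n2cccc21`) has only a limit, > 305000 nM, and that value is not an exact number. The next compound to be tested, compound 3 (`O=C1N(Cc2ccccc2Br)c2cccn2S(=O)(=O)N1Cc1ccccc1`), keeps the core of compound 1 but has 2-bromophenyl in place of 2,4-dichlorophenyl on a saturated chain carbon bound to an amide-type nitrogen in a ring. Within the data shown here, no pair of measured compounds differs in just one place, so no earlier step shows how large this change might be. The expectation therefore rests on compound 1 at 218000 nM. The estimated step of a 1.0-fold higher number from compound 1 to compound 3 (0.00 log units; within the scatter) is expected to stay within the usual scatter, with no clear direction in this assay. For compound 3, the estimated value is 220000 nM, with an expected range of 100000 nM to 420000 nM.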

Compound 3, half-maximal cytotoxic concentration: 226000 nM
Compound 3: the middle estimate sits 1.0-fold (0.01 log units) below what was measured, within the range that was stated.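

In this assay, the change from 2,4-dichlorobenzyl to 2-bromobenzyl gives a 1.0-fold higher number from compound 1 to compound 3 (0.02 log units; within the scatter). Within the data shown here, this is the only single-place step available, and it shows that compound 1 and compound 3 cannot be told apart in this assay, although two chlorine atoms give way to one bromine. Compound 2 has only a limit, not a number, and it adds no step: the limit of > 305000 nM in this assay, at which 1 of the 3 values shown sits.

Still open, from the compounds shown here alone, is whether a group of another kind at this place, such as an amine, a carboxylic acid or a phenyl without any halogen, would also stay within the scatter. The compounds shown also leave open what a longer chain in place of the 2-bromobenzyl would give.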